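This account rests on a few compounds, and the source may have more. Where it says the series, first, only, none or still open, it means among the compounds named here.

Measured so far:
- compound 1, `Nc1nc(O)nc2c1nc(O)n2Cc1ccccc1`: 0.1 uM
- compound 2, `Cc1ccc(Cn2c(O)nc3c(N)ncnc32)cc1`: 10 uM

Of the compounds shown here, two have been measured in a functional assay (spleen, spleen) for activation, with Mus musculus as the target; on this read-out lower numbers stand for an effect already at smaller amounts and higher numbers for an effect only at larger amounts of compound. Compound 1 `Nc1nc(O)nc2c1nc(O)n2Cc1ccccc1` gives 0.1 uM, the lowest of the two numbers. Among the compounds with values here, its nearest neighbour is compound 2 `Cc1ccc(Cn2c(O)nc3c(N)ncnc32)cc1`, which in this assay gives 10 uM, a gap well beyond the scatter; the two structures differ in more than one place, so the pair shows only that compound 1 acts at the smaller amount.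

The step under consideration leads from compound 1 to compound 3 `Nc1nc(SCc2ccccc2)nc2c1nc(O)n2Cc1ccccc1`. The change is benzylsulfanyl in place of hydroxy on an aromatic carbon, so a benzylsulfanyl group takes the place of the hydroxy on the aromatic carbon between two ring nitrogen atoms, meta to the amino group. Within the data shown here, no measured pair with this change exists, so its effect in this assay is not known from the data at hand. Given that compound 1 already stands at 0.1 uM, the author expects a step of modest size toward smaller numbers, though a step of no real size beyond the scatter cannot be excluded. For compound 3 the expected step is a 2.0-fold lower number from compound 1 to compound 3 (0.30 log units; within the scatter). The estimate for compound 3 is 0.05 uM, with a range from 0.005 uM to 0.5 uM.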

Compound 3, minimum effective concentration: 0.1 uM
For compound 3 the middle estimate is 2.0-fold (0.30 log units) below the measured one; the measured number falls inside the stated range.
By their numbers in this assay, from the lowest: compounds 1 and 3 (each within the scatter of the next); then compound 2.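

Going from hydroxy to benzylsulfanyl on the aromatic carbon between two ring nitrogen atoms gives, in this assay, no change at the digits printed from compound 1 to compound 3 (within the scatter), the first reading of this position, since compounds 1 and 2 differ in more than one place. This place on the core of compound 1 therefore accepts a far larger group in this whole-organism read-out: the hydroxy, a single oxygen with a hydrogen-bond donor, gives way to eight heavy atoms, including a six-membered aromatic ring of carbon only and a sulfur, and the two numbers remain within the scatter of each other. There is no evidence at hand that explains this result.

On these data alone, whether an amine or a carboxylic acid at this place, or a longer chain in place of the benzyl on the sulfur, would give a number like those of compound 1 and compound 3 remains open. A single pair also leaves open whether benzylsulfanyl would give the same result on a core with other substituents.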